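Replacing One Five-Membered Ring Group with Another

The source may report more compounds than this note shows. Statements on the series, on what has been measured and on what is new or still open speak of the compounds shown alone.

Compound 1, `Cc1nc(N2CCC(N3C(=O)CCC3=O)CC2)nc2ccc(NC(=O)/C=C/c3ccc(OC(F)(F)F)cc3)cc12`, carries a 2,5-dioxopyrrolidin-1-yl group on a saturated ring carbon of a six-membered non-aromatic ring with one nitrogen. In an ADME assay on microsomes from liver (Homo sapiens) for metabolic stability, with a stated time of 30 min (on this read-out higher numbers stand for a more stable compound and lower numbers for a less stable compound), compound 1 is recorded as "not determined" (no result reported), so it stands nowhere on the numbers shown here. For the measured compounds named here, the only measured value belongs to compound 2, `Cc1nc(N2CCC(N3CCCC3=O)CC2)nc2ccc(NC(=O)/C=C/c3ccc(Cl)cc3)cc12`, which in this assay gives 50%. Compound 3, `Cc1nc(N2CCC(N3CCN(C)C3=O)CC2)nc2ccc(NC(=O)/C=C/c3ccc(OC(F)(F)F)cc3)cc12`, differs from compound 1 in a single place: 3-methyl-2-oxoimidazolidin-1-yl in place of 2,5-dioxopyrrolidin-1-yl on a saturated ring carbon. Going by the values given here, no step between measured compounds is available to set the size or direction of this change in this assay, and compound 1 itself offers no number to start from; the step from compound 1 to compound 3 could lie within the scatter or beyond it in either direction. Because compound 2 gives 50% in this assay as the only anchor, compound 3 is expected to land near 45%, with an estimated range from 20% to 75%.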

Compound 3, percent of the compound remaining: 33%
Compound 3: middle estimate off by 12 percentage points, on the high side; low and high end bracket the measured number.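

In this assay, for the compounds shown here, compound 3 gives 33% and compound 1 offers no single number, so no step from compound 1 to compound 3 can be read. The compounds shown leave open how 3-methyl-2-oxoimidazolidin-1-yl compares with 2,5-dioxopyrrolidin-1-yl on this read-out. Nothing shown here bears on what lies behind the result for compound 3.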